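Methylating the sulfamoyl nitrogen of compound 2

The source may report more compounds than this note shows. Statements on the series, on what has been measured and on what is new or still open speak of the compounds shown alone.

Compound 2 `CCN1CCCC1CNC(=O)c1cc(NS(N)(=O)=O)ccc1OC` carries a sulfamoylamino group on an aromatic carbon of the shared core. In a functional assay on the whole organism for inhibition, with Mus musculus as the target (a lower number here means that less compound is needed, a higher number that more compound is needed for the effect), compound 2 reaches only a limit of the assay, > 50 mg/kg, so no number stands for it. Its nearest measured neighbour, compound 1 `CCN1CCCC1CNC(=O)c1cc(N(C)S(C)(=O)=O)ccc1OC`, bears methyl(methylsulfonyl)amino at the same carbon, and in this assay compound 1 gives 22.9 mg/kg. Going by the values given here, the single measured step is an at least 2.1-fold higher number from compound 1 to compound 2 (0.33 log units; beyond the scatter), which bundles two changes at once. Compound 3 `CCN1CCCC1CNC(=O)c1cc(N(C)S(N)(=O)=O)ccc1OC` differs from compound 2 by methyl in place of hydrogen on a sulfonamide nitrogen, which is only part of that step. Because compound 2 sits at the limit of > 50 mg/kg in this assay, at which 1 of the 2 values shown sits, the weight of the methyl alone cannot be separated out. The chemist expects compound 3 to fall between its two neighbours, with an at least 1.2-fold lower number from compound 2 to compound 3 (0.09 log units; that floor lies within the scatter) as the estimated step. The estimate for compound 3 in this assay is 40 mg/kg, within 15 mg/kg to 110 mg/kg.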

Compound 3, dose for half-maximal effect: > 50 mg/kg
Compound 3: only a limit was reported; the forecaster's own chance of this, stated with the estimate: 45%; middle value at least 1.2-fold (0.09 log units) from the limit.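

Compound 3 separates one part of the change that was bundled in the earlier step. With the methyl kept on the sulfonamide nitrogen, amino in place of methyl on the sulfonyl sulfur gives, in this assay, an at least 2.1-fold higher number from compound 1 to compound 3 (0.33 log units; beyond the scatter), so this change alone is enough to produce a shift beyond the scatter. The step for methyl in place of hydrogen on the sulfonamide nitrogen cannot be read, and that methyl shows no readable effect here because compound 2 and compound 3 both stop at a limit of the assay: the limit of > 50 mg/kg in this assay, at which 2 of the 3 values shown sit.

From the compounds shown here alone, how far compound 2 and compound 3 lie past that limit remains open, and so does the weight of the methyl on the sulfonamide nitrogen. Also open, going by these compounds, is whether ethyl or dimethylamino on the sulfonyl sulfur would give a number close to that of compound 1.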